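The source may hold more compounds than are shown below. What is called first, only, known or untested is meant among the compounds shown, and "the series" means these compounds.

Measured compounds:
compound 1 `Nc1n[nH]c2cc(-c3ccc(=O)n(Cc4ccccc4)c3)ccc12` — 32 nM
compound 2 `NC(=O)c1ccc(Cn2cc(-c3ccc4cn[nH]c4c3)ccc2=O)cc1` — > 2000 nM
compound 3 `O=c1ccc(-c2ccc3cn[nH]c3c2)cn1Cc1ccccc1C(F)(F)F` — 100 nM

In an assay for inhibition of MAP kinase-interacting serine/threonine-protein kinase 2 (Homo sapiens), read by luminescence and ADP-Glo, with a stated time of 2 h (on this read-out higher numbers stand for weaker inhibition and lower numbers for stronger inhibition), compound 1 gives 32 nM, the lowest of the two numbers given, with compound 3 the nearest of them at 100 nM, a gap beyond the scatter. Compound 2 gives only a limit of the assay, > 2000 nM, and no number; one of the three values sits at that limit (the limit of > 2000 nM in this assay, at which 1 of the 3 values shown sits).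

The step under consideration goes from compound 1 to compound 4 `O=c1ccc(-c2ccc3cn[nH]c3c2)cn1Cc1ccccc1`, not yet measured. The change is hydrogen in place of amino on an aromatic carbon: the amino group on an aromatic carbon of the five-membered aromatic ring with two nitrogens, part of the fused system, is replaced by hydrogen, while the benzyl group on the ring nitrogen is kept. Among the measured compounds shown here, no measured pair shows this change alone. Compound 3, which also lacks the amino group though with a trifluoromethyl on its benzyl ring, gives 100 nM. In this assay compound 4 is therefore expected to lose some potency relative to compound 1, with an estimated step of a 4.7-fold higher number from compound 1 to compound 4 (0.67 log units; beyond the scatter) weakening the inhibition beyond the scatter. The estimate for compound 4 is 150 nM, within 50 nM to 500 nM.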

Compound 4, half-maximal inhibitory concentration: 75 nM
Beside the measured number, compound 4's estimate is 2.0-fold (0.30 log units) above it, and the stated range covers the measured number.
By their numbers in this assay, from the lowest: compound 1; then compounds 4 and 3 (each within the scatter of the next). At a limit, above all of these: compound 2.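

In this assay, hydrogen in place of amino on the aromatic carbon gives a 2.3-fold higher number from compound 1 to compound 4 (0.37 log units; beyond the scatter), so this change, now seen alone, costs only a modest part of the inhibition, and compound 4 still inhibits without the amino group. On the benzyl ring the two substituents part ways: hydrogen in place of trifluoromethyl gives a 1.3-fold lower number from compound 3 to compound 4 (0.12 log units; within the scatter), while hydrogen in place of carbamoyl gives an at least 26-fold lower number from compound 2 to compound 4 (1.42 log units; beyond the scatter). The second step rests on a limit of the assay and not a number, so its true size is unknown: the limit of > 2000 nM in this assay, at which 1 of the 4 values shown sits.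

The compounds shown leave open how a methyl group or a methylamino group on that same aromatic carbon would read against amino and hydrogen. They also leave open whether a nitrile or a carboxylic acid on the benzyl ring would behave like trifluoromethyl or like carbamoyl.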